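The compounds below may be only part of what the source reports. "The series", "measured", "known", "first", "only" and "open" are said of these compounds alone.

Measured in a functional assay on A549 cells (Homo sapiens) for antiproliferative activity, read by MTT assay, with a stated time of 48 h; on this read-out lower numbers stand for stronger inhibition and higher numbers for weaker inhibition:

compound 1 `CNCC(=O)Nc1cc(OC)ccc1C(=O)c1cc(OC)c(OC)c(OC)c1`, compound 1 gives 610 nM
compound 2 `CCNCC(=O)Nc1cc(OC)ccc1C(=O)c1cc(OC)c(OC)c(OC)c1`, compound 2 gives 750 nM
compound 3 `C=C(c1ccc2c(c1)C=CC(C)(C)O2)c1ccc(OC)cc1NC(=O)CNC`, compound 3 gives 200 nM

Within the data shown here, from compound 1 to compound 2 the only change is methyl in place of hydrogen on a saturated chain carbon bound to an amine nitrogen, and the result was a 1.2-fold higher number from compound 1 to compound 2 (0.09 log units; within the scatter). Compound 3 carries a different core; how its core differs from that of compound 1 is not broken down here, but its number is the lowest of the three, and its steps to compound 1 and to compound 2 both lie beyond the scatter.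

Compound 4 `C=C(c1ccc2c(c1)C=CC(C)(C)O2)c1ccc(OC)cc1NC(=O)CNCC` is built from compound 3 by the same change, (methyl in place of hydrogen on a saturated chain carbon bound to an amine nitrogen), made at the same place. The expectation is a step of about a 1.2-fold higher number from compound 3 to compound 4 (0.08 log units; within the scatter), resting on the earlier step of a 1.2-fold higher number from compound 1 to compound 2 (0.09 log units; within the scatter), which was within the scatter. For compound 4 in this assay the estimate is 240 nM, likely between 120 nM and 480 nM.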

Compound 4, half-maximal inhibitory concentration: 1180 nM
The estimate for compound 4 lay 4.9-fold (0.69 log units) below the measured number, outside the stated range (above it).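

Measured in this assay the change from methylamino to ethylamino gave a 5.9-fold higher number from compound 3 to compound 4 (0.77 log units; beyond the scatter) on the core of compound 3, a clear loss of activity. Set beside the earlier result, the same small change did not have the same size on the two cores: the same change on two cores in this assay, a 1.2-fold higher number (0.09 log units; within the scatter) from compound 1 to compound 2 and a 5.9-fold higher number (0.77 log units; beyond the scatter) from compound 3 to compound 4, 4.8-fold (0.68 log units) apart, beyond the scatter of two such steps

A step read on one core in this series therefore cannot simply be carried over to the other, but these two pairs do not show which part of the cores matters or why the steps differ.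

The compounds shown leave open how a longer chain, such as propylamino, would behave on each core. They also leave open whether a dimethylamino group would show the same gap between the cores.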